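The source may report more compounds than this note shows. Statements on the series, on what has been measured and on what is new or still open speak of the compounds shown alone.

Compound 2 `C=C1C(=O)[C@]23C[C@@]1(O)CC[C@H]2c1ccc(O)c(C)c1[C@@H]3Cn1cc(-c2ccc(F)cc2)nn1` gives 940 nM in a functional assay on A549 cells (Homo sapiens) for cytotoxicity, read by MTT assay, with a stated time of 4 days (on this read-out higher numbers stand for weaker inhibition and lower numbers for stronger inhibition), the lowest of the three numbers measured, although compound 1 `C=C1C(=O)[C@]23C[C@@]1(O)CC[C@H]2c1ccc(O)c(C)c1[C@@H]3Cn1cc(-c2ccccc2)nn1` with 1160 nM sits within the scatter of it, as the step of a 1.2-fold lower number from compound 1 to compound 2 (0.09 log units; within the scatter) shows. Compound 3 `C=C1C(=O)[C@]23C[C@@]1(O)CC[C@H]2c1ccc(OS(=O)(=O)c2ccc(C)cc2)c(C)c1[C@@H]3Cn1cc(-c2ccc(F)cc2)nn1` gives 1950 nM, a step of a 2.1-fold higher number from compound 2 to compound 3 (0.32 log units; beyond the scatter) that is modest but beyond the scatter. Compound 4 `C=C1C(=O)[C@]23C[C@@]1(O)CC[C@H]2c1ccc(O)c(C)c1[C@@H]3Cn1cc(-c2ccc(OC)cc2)nn1` differs from compound 2 by methoxy in place of fluoro on an aromatic carbon. Among the compounds with values here, the only step that bears on this position, from compound 1 to compound 2, was within the scatter, so the substituent on this phenyl ring has so far moved this assay little; the step of a 2.1-fold higher number from compound 2 to compound 3 (0.32 log units; beyond the scatter) concerns another site. For compound 4 a step of a 1.1-fold higher number from compound 2 to compound 4 (0.05 log units; within the scatter) is therefore expected, none beyond the scatter. The estimate for compound 4 is 1050 nM, with a range of 500 nM to 2200 nM.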

Compound 4, half-maximal inhibitory concentration: 1250 nM
Compound 4: middle estimate off by 1.2-fold (0.08 log units), on the low side, and the stated range covers the measured number.
By their numbers in this assay, from the lowest: compounds 2, 1, 4 and 3 (each within the scatter of the next, the first and the last beyond it).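

Methoxy, the first group at this position that carries an oxygen, also leaves the number within the scatter in (this assay), both against fluoro (a 1.3-fold higher number from compound 2 to compound 4 (0.12 log units; within the scatter)) and against hydrogen (a 1.1-fold higher number from compound 1 to compound 4 (0.03 log units; within the scatter)). Hydrogen, fluoro and methoxy on this aromatic carbon, para to a large group, are therefore not told apart by this read-out. Nothing available gives a reason for this.

Open, as far as these compounds go, is whether an amine or a carboxylic acid at this position would give a step beyond the scatter, and whether the (4-methylphenyl)sulfonyl step seen with the 4-fluorophenyl compounds holds with 4-methoxyphenyl.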